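Nitro for Methoxy: Expecting the Value of Compound 4

The compounds below may be only part of what the source reports. "The series", "measured", "known", "first", "only" and "open" are said of these compounds alone.

Of the compounds shown here, three built on one shared core have been measured in a functional assay on A2780 cells (Homo sapiens) for antiproliferative activity, read by MTT assay, with a stated time of 72 h; a higher number here means a weaker inhibitor, a lower number a stronger inhibitor. Compound 1 `O=C(c1cc2ccccc2o1)N1N=C(c2ccccc2)CC1c1ccc([N+](=O)[O-])cc1` gives 4.87 ug/mL in this assay. Compound 2 `COc1ccc(C2CC(c3ccccc3)=NN2C(=O)c2cc3ccccc3o2)cc1` gives 4.57 ug/mL in this assay. Compound 3 `COc1ccc(C2CC(c3ccc(Cl)cc3)=NN2C(=O)c2cc3ccccc3o2)cc1` gives 5.74 ug/mL in this assay, and its two neighbours sit close to it.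

Compound 3 differs from compound 2 by chloro in place of hydrogen on an aromatic carbon, a change that made the step of a 1.3-fold higher number from compound 2 to compound 3 (0.10 log units; within the scatter). Compound 1 differs from compound 2 by nitro in place of methoxy on an aromatic carbon, and this change made the step of a 1.1-fold higher number from compound 2 to compound 1 (0.03 log units; within the scatter).

Compound 4 `O=C(c1cc2ccccc2o1)N1N=C(c2ccc(Cl)cc2)CC1c1ccc([N+](=O)[O-])cc1` has not yet been measured in this assay. It differs from compound 3 by nitro in place of methoxy on an aromatic carbon, which is the same change as that from compound 2 to compound 1, at the same kind of place on the same kind of ring. Because the earlier step of a 1.1-fold higher number from compound 2 to compound 1 (0.03 log units; within the scatter) lay within the scatter, the step of a 1.1-fold higher number from compound 3 to compound 4 (0.03 log units; within the scatter) is expected to be similarly small. Compound 4 is therefore estimated to give 6.1 ug/mL in this assay, with a likely range from 3.5 ug/mL to 10.5 ug/mL.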

Compound 4, half-maximal inhibitory concentration: 34.1 ug/mL
Estimate against measurement, compound 4: 5.6-fold (0.75 log units) below; the whole stated range lies below it.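

In this assay, nitro in place of methoxy did not behave alike on the two cores, and the step of a 5.9-fold higher number from compound 3 to compound 4 (0.77 log units; beyond the scatter) does not repeat the small step seen on the core of compound 2: the same change on two cores in this assay, a 1.1-fold higher number (0.03 log units; within the scatter) from compound 2 to compound 1 and a 5.9-fold higher number (0.77 log units; beyond the scatter) from compound 3 to compound 4, 5.6-fold (0.75 log units) apart, beyond the scatter of two such steps. Read the other way, chloro in place of hydrogen gives a 7.0-fold higher number from compound 1 to compound 4 (0.85 log units; beyond the scatter) and likewise differs from its earlier counterpart: the same change on two cores in this assay, a 1.3-fold higher number (0.10 log units; within the scatter) from compound 2 to compound 3 and a 7.0-fold higher number (0.85 log units; beyond the scatter) from compound 1 to compound 4, 5.6-fold (0.75 log units) apart, beyond the scatter of two such steps. These four compounds thus show that the two changes do not simply add, with the larger number appearing only in compound 4, which carries both nitro and chloro; they do not show why this happens, and one pair per core gives no rule for other cores.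

The compounds shown leave open whether a similar rise would appear with an amine or a carboxylic acid in place of the nitro, or with fluoro or methyl in place of the chloro. They also leave open whether the pattern holds in any other cell line.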